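Ether side chain: propoxy to 2-methoxyethoxy

This account rests on a few compounds, and the source may have more. Where it says the series, first, only, none or still open, it means among the compounds named here.

Measured so far in a functional assay on HeLa cells (Homo sapiens) for antiproliferative activity; a lower number here means a stronger inhibitor, a higher number a weaker inhibitor:
- compound 1 `CCCCO/N=C/c1c(N)ncnc1Oc1ccc2[nH]c(C)cc2c1F` gives 607 nM 
- compound 2 `Cc1cc2c(F)c(Oc3ncnc(N)c3/C=N/OCc3ccccc3)ccc2[nH]1` gives 266 nM 
- compound 3 `CCCO/N=C/c1c(N)ncnc1Oc1ccc2[nH]c(C)cc2c1F` gives 40 nM 

Compound 3 has the lowest number of the three, and both other compounds lie beyond the scatter from it. Compound 4 `COCCO/N=C/c1c(N)ncnc1Oc1ccc2[nH]c(C)cc2c1F` has not yet been measured. The change from compound 3 is methoxy in place of methyl on a saturated chain carbon, two bonds along the chain from an oxygen on an unsaturated carbon and reads, cut one bond further out, propoxy to 2-methoxyethoxy.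

For the measured compounds named here, two measured steps bear on this change. One is a 15-fold lower number from compound 1 to compound 3 (1.18 log units; beyond the scatter) with hydrogen in place of methyl on the chain, and it is large. The other is a 6.7-fold lower number from compound 2 to compound 3 (0.82 log units; beyond the scatter) with ethyl in place of phenyl, and it is modest. Among these three compounds, both departures from the propoxy chain of compound 3 give a higher number, and none goes against this. Going by the values given here, no measured compound carries methoxy on the chain, so these steps are only a loose guide. A modest step to a higher number is therefore expected in this assay and not a large one. The estimate amounts to a 3.0-fold higher number from compound 3 to compound 4 (0.48 log units; beyond the scatter) as an expectation only. Compound 4 is expected at 120 nM with an estimated range of 35 nM to 420 nM in this measurement.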

Compound 4, half-maximal inhibitory concentration: 308 nM
Beside the measured number, compound 4's estimate is 2.6-fold (0.41 log units) below it; the range from low to high includes it.
By their numbers in this assay, from the lowest: compound 3; then compounds 2, 4 and 1 (each within the scatter of the next, the first and the last beyond it).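

In this assay, methoxy in place of methyl at this place on the chain gives a 7.7-fold higher number from compound 3 to compound 4 (0.89 log units; beyond the scatter), so the propoxy chain of compound 3 now holds the lowest number against three different departures, with none among these four compounds going the other way. The oxygen-bearing chain does not separate compound 4 from either of the other two departures: the comparison with the phenyl-bearing compound gives a 1.2-fold higher number from compound 2 to compound 4 (0.06 log units; within the scatter), and the comparison with the longer all-carbon chain gives a 2.0-fold lower number from compound 1 to compound 4 (0.29 log units; within the scatter), both within the scatter. No measured evidence on the cause of the step from compound 3 to compound 4 is available here.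

Still open, going by these compounds, is how sharply the number depends on the propoxy chain itself, since an ethoxy chain on the shared core would show whether shortening the chain also gives a higher number. Equally open, on these data alone, is whether the step seen with compound 4 is particular to methoxy or extends to other end groups, such as a 2-hydroxyethoxy or 2-aminoethoxy chain.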